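This account rests on a few compounds, and the source may have more. Where it says the series, first, only, none or still open, it means among the compounds named here.

Three compounds share one core. Compound 1 `COc1cc(-c2cc(/C=C/C(=O)c3ccc(N)cc3)[nH]n2)cc(OC)c1OC` gives 91% in a functional assay on UO-31 cells (Homo sapiens) for cytotoxicity, read by sulforhodamine B assay, with a stated time of 48 h, tested at 0.1 uM; a lower number here means a stronger effect, a higher number a weaker effect of the compound at the concentration tested. Compound 2 `COc1cc(-c2cc(/C=C/C(=O)c3ccc(Cl)c(Cl)c3)[nH]n2)cc(OC)c1OC` gives 85%, and compound 3 `COc1ccc(C(=O)/C=C/c2cc(-c3cc(OC)c(OC)c(OC)c3)n[nH]2)cc1OC` gives 87%. Compound 3 stands second highest of these three numbers; the steps of a number 2 percentage points higher from compound 2 to compound 3 (within the scatter) and a number 4 percentage points lower from compound 1 to compound 3 (within the scatter) both lie within the scatter. Compound 4 `COc1ccc(C(=O)/C=C/c2cc(-c3cc(OC)c(OC)c(OC)c3)n[nH]2)cc1` differs from compound 3 by hydrogen in place of methoxy on an aromatic carbon. Among the measured compounds shown here, no measured step swaps a methoxy for a hydrogen; the known steps of a number 6 percentage points lower from compound 1 to compound 2 (within the scatter), a number 4 percentage points lower from compound 1 to compound 3 (within the scatter) and a number 2 percentage points higher from compound 2 to compound 3 (within the scatter) each change the group on the carbonyl carbon, and all stay within the scatter. The step of a number 1 percentage points higher from compound 3 to compound 4 (within the scatter) is therefore expected to lie within the scatter as well. Compound 4 is estimated at 88%, between 78% and 97%.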

Compound 4, a percentage reported as activity, at one concentration (the size of the read-out at that concentration, not a potency): 96%
Beside the measured number, compound 4's estimate is 8 percentage points below it; the range from low to high includes it.
By their numbers in this assay, from the lowest: compounds 2, 3, 1 and 4 (each within the scatter of the next, the first and the last beyond it).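

Taking one methoxy off the aromatic ring, turning 3,4-dimethoxyphenyl into 4-methoxyphenyl, is the first change here that alters a single group on that ring, and in this assay the step (a number 9 percentage points higher from compound 3 to compound 4 (within the scatter)) shows that this methoxy can go without a clear loss or gain. Methoxy in place of amino gives a similar picture (a number 5 percentage points higher from compound 1 to compound 4 (within the scatter)), whereas 4-methoxyphenyl in place of 3,4-dichlorophenyl gives the first step to pass the scatter, though only modestly (a number 11 percentage points higher from compound 2 to compound 4 (beyond the scatter)). No measured evidence bears on why these numbers fall as they do. From the compounds shown here alone, whether a hydroxy group, a fluorine or an amine on that same aromatic carbon would shift the number remains open.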